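Cyclopropyl gives way to ethyl in compound 4

This account rests on a few compounds, and the source may have more. Where it says the series, first, only, none or still open, it means among the compounds named here.

Measured so far in an ADME assay (liver) for metabolic stability, with Liver microsome (Canis lupus familiaris) as the target, read by LC-MS, using microsomes, with a stated time of 30 min, tested at 4 uM; a higher number here means that more of the compound is left, a lower number that less of the compound is left:
Compound 1 `Cc1nc(N2CCN(C)CC2)c2nc(-c3ccccc3C(F)(F)F)n(C3CCOCC3)c2n1` gives 61%
Compound 2 `Cc1nc(N2CCN(C)CC2)c2nc(-c3ccccc3C#N)n(C3CCOCC3)c2n1` gives 11%
Compound 3 `Cc1nc(N2CCN(C)CC2)c2nc(-c3ccccc3C3CC3)n(C3CCOCC3)c2n1` gives 69%

Compound 3 stands at 69% and has one close neighbour and one distant one: the steps read a number 8 percentage points higher from compound 1 to compound 3 (within the scatter) and a number 58 percentage points higher from compound 2 to compound 3 (beyond the scatter) on the same scale. Compound 4 `CCc1ccccc1-c1nc2c(N3CCN(C)CC3)nc(C)nc2n1C1CCOCC1` alters a single group (ethyl in place of cyclopropyl on an aromatic carbon), with ethyl in place of cyclopropyl on an aromatic carbon, ortho to a large group.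

Among the compounds with values here, no measured step makes this exact exchange, and three compounds are a thin basis. The closest evidence is the exchange between trifluoromethyl and cyclopropyl (a number 8 percentage points higher from compound 1 to compound 3 (within the scatter)), which stayed within the scatter. Within the data shown here, the one large change among the aromatic groups came with the nitrile (a number 50 percentage points lower from compound 1 to compound 2 (beyond the scatter)), and ethyl is not a nitrile. In this assay a step beyond the scatter is therefore not expected, though a small downward drift is thought more likely than a rise. The expected step is a number 9 percentage points lower from compound 3 to compound 4 (within the scatter) and remains an estimate. Compound 4 is estimated at 60% with an expected range from 40% to 76% in this reading.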

Compound 4, percent of the compound remaining: 74%
Compound 4: the middle estimate sits 14 percentage points below what was measured, and the stated range covers the measured number.
By their numbers in this assay, from the lowest: compound 2; then compounds 1, 3 and 4 (each within the scatter of the next, the first and the last beyond it).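

In this assay, a ring is not required at this place on the aromatic ring: ethyl, which has no ring, cannot be told apart from cyclopropyl in the change from 2-cyclopropylphenyl to 2-ethylphenyl (a number 5 percentage points higher from compound 3 to compound 4 (within the scatter)). The new compound also gives the first step from trifluoromethyl that is beyond the scatter without being a fall (a number 13 percentage points higher from compound 1 to compound 4 (beyond the scatter)), whereas cyclopropyl had stayed within the scatter of trifluoromethyl (a number 8 percentage points higher from compound 1 to compound 3 (within the scatter)), so compounds 1, 3 and 4 form a graded run in which only the two ends are separated. Within the data shown here, the nitrile of compound 2 remains the only group far below the others, and the step to ethyl is the largest in the set so far (a number 63 percentage points higher from compound 2 to compound 4 (beyond the scatter)).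

Nothing available explains why the nitrile stands apart or why ethyl and trifluoromethyl separate. The compounds shown leave open whether a longer chain such as propyl, a branched isopropyl or a methoxy group at this place would stay level with ethyl, and whether an amine or a carboxylic acid there would fall as far as the nitrile.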